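Disulfide substituent series, stability notes

The source may report more compounds than this note shows. Statements on the series, on what has been measured and on what is new or still open speak of the compounds shown alone.

Measured so far:
- compound 1 `Cc1cn([C@H]2C[C@H](SSc3ccccc3[N+](=O)[O-])[C@@H](CO)O2)c(=O)[nH]c1=O`: in a physicochemical assay for metabolic stability, in the presence of a further agent that is not named here (on this read-out lower numbers stand for a shorter-lived compound and higher numbers for a longer-lived compound), compound 1 gives a limit, < 0.167 h
- compound 2 `CCCCCCSS[C@H]1C[C@H](n2cc(C)c(=O)[nH]c2=O)O[C@@H]1CO`: in this assay compound 2 gives a limit, < 8 h
- compound 3 `CCCCCCCCSS[C@H]1C[C@H](n2cc(C)c(=O)[nH]c2=O)O[C@@H]1CO`: in this assay compound 3 gives a limit, < 8 h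

Compound 3 stands at a limit of this assay and not at a number. Compound 2 also sits at that limit (the limit of < 8 h in this assay, at which 2 of the 3 values shown sit). Compound 1 sits at a different limit (the limit of < 0.167 h in this assay, at which 1 of the 3 values shown sits). Of the measured steps, a step that the two limits leave unreadable from compound 1 to compound 2, a step that the two limits leave unreadable from compound 1 to compound 3 and a step that the two limits leave unreadable from compound 2 to compound 3 are all left unreadable by the limits, so no size and no direction can be taken from any of them.

Compound 4 `Cc1cn([C@H]2C[C@H](SSCCO)[C@@H](CO)O2)c(=O)[nH]c1=O` differs from compound 3 by hydroxy in place of hexyl on a saturated chain carbon, two bonds along the chain from a sulfur. Among the compounds with values here, no measured step bears readably on this change; the only one touching a chain carbon, a step that the two limits leave unreadable from compound 2 to compound 3, has no readable size. No step beyond the scatter can therefore be argued in either direction, and a limit is again the most likely read-out.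

Compound 4 is expected to give about 4 h in this assay, within 0.5 h to 8 h. The expected step is a step that the limit leaves unreadable from compound 3 to compound 4.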

Compound 4, half-life: < 8 h
Compound 4: only a limit was reported; the forecaster's own chance of this, stated with the estimate: 60%; the middle value does not contradict the limit.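

In this assay compound 4 gives a limit, < 8 h. The steps linking compound 4 to compound 1, compound 2 and compound 3 all run between limits and cannot be read. The compounds shown leave open how long any of these four disulfides actually lasts, and whether any substituent change alters it.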